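The compounds below may be only part of what the source reports. "The series", "measured", "known", "first", "only" and "open" are said of these compounds alone.

Compound 1 `N#CC1=C(N)Oc2c(c3nc4ccccc4nc3c3ccccc23)C12C(=O)N(Cc1cnnn1-c1ccccc1Br)c1ccccc12`: in a functional assay on MCF7 cells (Homo sapiens) for antiproliferative activity, read by MTT assay, with a stated time of 48 h (a lower number here means a stronger inhibitor, a higher number a weaker inhibitor), compound 1 gives > 50000 nM, which is a limit of the assay and not a number.
Compound 2 `N#CC1=C(N)Oc2c(c3nc4ccccc4nc3c3ccccc23)C12C(=O)N(Cc1cnnn1-c1cccc(Br)c1)c1ccccc12`: in this assay compound 2 gives > 50000 nM, again a limit of the assay.
Compound 3 `CCc1ccccc1-n1nncc1CN1C(=O)C2(C(C#N)=C(N)Oc3c(N)cc4nc5ccccc5nc4c32)c2ccccc21`: in this assay compound 3 gives 24600 nM.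

For the measured compounds named here, compound 3 therefore holds the only numerical value among the three; the other two sit at a limit (the limit of > 50000 nM in this assay, at which 2 of the 3 values shown sit). The step that the two limits leave unreadable from compound 1 to compound 2 cannot be read, since both of its ends are limits. Between compound 3 and either of the other two no single-point step exists, and their values show only that compound 3 returns a number where compound 1 and compound 2 do not.

Compound 4 `COc1ccc(OC)c(-n2nncc2CN2C(=O)C3(C(C#N)=C(N)Oc4c(N)cc5nc6ccccc6nc5c43)c3ccccc32)c1` differs from compound 3 as 2,5-dimethoxyphenyl in place of 2-ethylphenyl on an aromatic nitrogen. None of the measured steps bears on this change: the one step shown is unreadable and concerns a bromophenyl at the same position, not the group exchanged here. The data thus give no basis for a step beyond the usual scatter in either direction, and a step within the scatter is expected. The estimate for compound 4 in this assay is 30000 nM, with a range of 10000 nM to 100000 nM. The expected step of a 1.2-fold higher number from compound 3 to compound 4 (0.09 log units; within the scatter) is accordingly small. Compound 3 already stands at 24600 nM. For compound 4, too, a reading that the assay cannot give as a number cannot be ruled out.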

Compound 4, half-maximal inhibitory concentration: 28100 nM
Compound 4: middle estimate off by 1.1-fold (0.03 log units), on the high side, and the stated range covers the measured number.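

In this assay, for the compounds shown here, the first readable step at this place, on an aromatic nitrogen of a five-membered aromatic ring with 3 nitrogen, is a 1.1-fold higher number from compound 3 to compound 4 (0.06 log units; within the scatter). The exchange takes the group from 2-ethylphenyl, with 8 heavy atoms and 0 hydrogen-bond acceptors, to 2,5-dimethoxyphenyl, with 10 heavy atoms and 2 hydrogen-bond acceptors, while the six-membered aromatic ring of carbon only stays, and the two numbers remain within the scatter of each other. Compound 1 and compound 2 stay at a limit of the assay, and the step joining them cannot be read: the limit of > 50000 nM in this assay, at which 2 of the 4 values shown sit.

Still open, from the compounds shown here alone, is whether any group at this place moves the number beyond the scatter, for example a phenyl ring carrying an amine or a carboxylic acid, or a longer alkyl chain in place of the ring. With a single readable step, the two substituted phenyl groups compared here do not establish a trend for this place, and the effect of any single substituent on the ring remains unresolved.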